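The source may report more compounds than this note shows. Statements on the series, on what has been measured and on what is new or still open speak of the compounds shown alone.

Measured compounds:
- compound 1, `Nc1nn(C(=O)Nc2ccc(Cc3ccccc3)cc2)c2ccccc12`, in a functional assay on OVCAR-8 cells (Homo sapiens) for antiproliferative activity, read by sulforhodamine B assay, with a stated time of 48 h (a lower number here means a stronger inhibitor of growth, a higher number a weaker inhibitor of growth), gives 21900 nM
- compound 2, `Nc1nn(C(=O)Nc2ccc(Cc3ccccc3)cc2)c2ccc(Cl)cc12`, in this assay gives 14900 nM

Compound 2 carries a chloro group on the shared core where compound 1 has only hydrogen. Among the two numbers so far, compound 2 has the lower one, but the gap to compound 1 is small: a 1.5-fold lower number from compound 1 to compound 2 (0.17 log units; within the scatter), a difference that falls within the ordinary scatter of the measurement, so the two compounds cannot be told apart in this assay on this evidence.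

Compound 3, `Nc1ccc2c(c1)c(N)nn2C(=O)Nc1ccc(Cc2ccccc2)cc1`, is the next step: amino in place of chloro on an aromatic carbon. Within the data shown here, the only measured step that bears on this position is the one from compound 1 to compound 2, which swapped hydrogen for chloro at the same place and produced no change beyond the scatter. That step says the position tolerates a small substituent without a clear effect, but it gives no direct information on an amino group there. With nothing to point either way, no step beyond the scatter is expected in this assay for compound 3, and the estimate for compound 3 is 18000 nM, within a range from 7000 nM to 45000 nM, which means a 1.2-fold higher number from compound 2 to compound 3 (0.08 log units; within the scatter).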

Compound 3, concentration for 50% growth inhibition: 20200 nM
The estimate for compound 3 lay 1.1-fold (0.05 log units) below the measured number; the measured number falls inside the stated range.
By their numbers in this assay, from the lowest: compounds 2, 3 and 1 (each within the scatter of the next).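

In this assay, amino in place of chloro on this aromatic carbon gives only a small step (a 1.4-fold higher number from compound 2 to compound 3 (0.13 log units; within the scatter)), and amino in place of hydrogen gives another (a 1.1-fold lower number from compound 1 to compound 3 (0.04 log units; within the scatter)). Until now the position had been probed only with chloro against hydrogen; it now holds three different groups, one of which adds a hydrogen-bond donor and a hydrogen-bond acceptor by the computed count, and none of the steps among them goes beyond the scatter, so this position has not yet shown any group that separates one compound from another. Nothing measured here explains why the numbers stay so close together.

From the compounds shown here alone, whether any group at this place can shift the number beyond the scatter remains open, since a carboxylic acid, a methoxy group or a longer chain such as butyl might behave differently from the three groups seen so far. Also open, going by these compounds, is whether changes elsewhere on the shared core, or on the rest of the molecule, would matter more than this one does.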